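Swapping the amide substituent on a shared core

The source may report more compounds than this note shows. Statements on the series, on what has been measured and on what is new or still open speak of the compounds shown alone.

Three compounds share one core and differ only in the group attached to the amide carbonyl. Compound 1 `CN(C)C(=O)c1ccncc1Nc1cc(-c2ccc3ccn(C)c3c2)c2nccnc2c1` carries a dimethylamino group on the carbonyl carbon, and in an assay for inhibition of 6-phosphofructo-2-kinase/fructose-2,6-bisphosphatase 3 (Homo sapiens), read by ADP-Glo, with a stated time of 2 h (on this read-out higher numbers stand for weaker inhibition and lower numbers for stronger inhibition), compound 1 gives 499 nM. Compound 2 `Cn1cc(NC(=O)c2ccncc2Nc2cc(-c3ccc4ccn(C)c4c3)c3nccnc3c2)cn1` gives 33 nM, and compound 3 `CN1CCC(NC(=O)c2ccncc2Nc2cc(-c3ccc4ccn(C)c4c3)c3nccnc3c2)CC1=O` gives 41 nM. Among these three numbers compound 3 stands second highest: close to compound 2, and far from compound 1.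

Compound 4 `Cn1ccc2ccc(-c3cc(Nc4cnccc4C(=O)NCC4COCCN4)cc4nccnc34)cc21` is the next step from compound 3: (morpholin-3-yl)methyl in place of 1-methyl-2-oxopiperidin-4-yl on an amide-type nitrogen.

Two kinds of measured step bear on this change. Replacing the dimethylamino group by a substituted amino group lowered the number strongly in both cases seen: a 15-fold lower number from compound 1 to compound 2 (1.18 log units; beyond the scatter) and a 12-fold lower number from compound 1 to compound 3 (1.09 log units; beyond the scatter). Among the measured compounds shown here, the one step that, like this one, exchanges only the group on the amide nitrogen while keeping a substituted amino group left the number essentially where it was: a 1.2-fold higher number from compound 2 to compound 3 (0.09 log units; within the scatter). Compound 4 keeps a substituted amino group on the carbonyl carbon, so the expected step is a 1.2-fold higher number from compound 3 to compound 4 (0.09 log units; within the scatter), nothing beyond the scatter. Compound 4 is therefore estimated at 50 nM, with a range from 15 nM to 170 nM.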

Compound 4, half-maximal inhibitory concentration: 33 nM
Estimate against measurement, compound 4: 1.5-fold (0.18 log units) above; the measured number falls inside the stated range.
By their numbers in this assay, from the lowest: compounds 2, 4 and 3 (each within the scatter of the next); then compound 1.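

With a 1.2-fold lower number from compound 3 to compound 4 (0.09 log units; within the scatter) and no change at the digits printed from compound 2 to compound 4 (within the scatter) both within the scatter in this assay, a third group on the amide-type nitrogen now sits with the other two, even though (morpholin-3-yl)methyl has a six-membered ring with 2 hetero atoms and a hydrogen-bond donor that 1-methyl-2-oxopiperidin-4-yl lacks. Among compounds 2, 3 and 4, then, three different rings on this nitrogen give numbers that cannot be told apart, and here the ring is attached through a methyl link rather than directly. Among the compounds shown here, the only large gap remains the one to the dimethylamino group, seen again in a 15-fold lower number from compound 1 to compound 4 (1.18 log units; beyond the scatter) and matching the two earlier steps from compound 1.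

Compound 1 differs from the other three in two ways at once, having neither the amide hydrogen nor a ring on this nitrogen, so a methylamino group or an open chain such as 2-methoxyethylamino on the carbonyl carbon would be needed to separate the two. Nothing measured here explains why these three groups give such similar numbers or why the dimethylamino compound stands apart.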